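This account rests on a few compounds, and the source may have more. Where it says the series, first, only, none or still open, it means among the compounds named here.

In an ADME assay on Vero cells (Chlorocebus sabaeus) for inhibition (a lower number here means that less compound is tolerated, a higher number that more compound is tolerated), compound 1 `COc1ccc(/C=C2\CCC/C(=C\c3ccc(OC)cc3)C2=O)cc1` gives 178000 nM and holds the second highest of three numbers. Compound 3 `O=C1/C(=C/c2c(Cl)cccc2Cl)CCC/C1=C\c1c(Cl)cccc1Cl` stands higher at 574000 nM and compound 2 `O=C1/C(=C/c2ccc(Cl)cc2)CCC/C1=C\c1ccc(Cl)cc1` stands lower at 32100 nM with both gaps to compound 1 beyond the scatter. The change to compound 4 `COc1ccc(/C=C2\CCC/C(=C\c3ccc(Br)cc3)C2=O)cc1` is bromo in place of methoxy on an aromatic carbon with bromo in place of methoxy on an aromatic carbon, para to a large group. Among the measured compounds shown here, no measured pair shows this change alone. The halogen-bearing compound 2 at 32100 nM points to a lower number, while the halogen-bearing compound 3 at 574000 nM goes against that, so the expectation stays loose. A modest drop is expected in this assay with a 2.4-fold lower number from compound 1 to compound 4 (0.38 log units; beyond the scatter) as the estimated step. Compound 4 is estimated at 75000 nM within an expected range of 25000 nM to 220000 nM for now.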

Compound 4, half-maximal cytotoxic concentration: 250000 nM
Compound 4: middle estimate off by 3.3-fold (0.52 log units), on the low side; the whole stated range lies below it.
By their numbers in this assay, from the lowest: compound 2; then compounds 1 and 4 (each within the scatter of the next); then compound 3.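

In this assay, among the compounds shown here, the change from 4-methoxyphenyl to 4-bromophenyl on one side of the core gives a 1.4-fold higher number from compound 1 to compound 4 (0.15 log units; within the scatter) and so offers the first comparison of compounds that differ in one place. At this position, with methoxy kept on the other side, bromo and methoxy cannot be told apart in this read-out. Nothing measured here bears on why the two groups read alike.

Going by these compounds, whether an amine or a carboxylic acid at this position would also leave the number within the scatter stays open. So does whether replacing the remaining methoxy with bromo would do the same.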